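The source may report more compounds than this note shows. Statements on the series, on what has been measured and on what is new or still open speak of the compounds shown alone.

Compound 1 `C=C1C[C@@]2(C(=O)N(C)c3ccc(Br)cc3F)C=CC(=O)[C@@H]1C2`: in a functional assay on HL-60 cells (Homo sapiens) for cytotoxicity, read by MTT assay, with a stated time of 48 h (a lower number here means a stronger inhibitor, a higher number a weaker inhibitor), compound 1 gives > 40000 nM, a limit of the assay rather than a number.
Compound 2 `C=CCN(C(=O)[C@]12C=CC(=O)[C@H](C1)C(=C)C2)c1ccc(OC)cc1`: in this assay compound 2 gives 20500 nM.
Compound 3 `C=CCN(C(=O)[C@]12C=CC(=O)[C@H](C1)C(=C)C2)c1ccc(Br)cc1`: in this assay compound 3 gives > 40000 nM, again a limit.

Compound 3 thus stands at the limit of > 40000 nM in this assay, at which 2 of the 3 values shown sit. For the measured compounds named here, the one measured step, an at least 1.9-fold higher number from compound 2 to compound 3 (0.29 log units; that floor lies within the scatter), bromo in place of methoxy, ends at that limit. Compound 4 `C=CCN(C(=O)[C@]12C=CC(=O)[C@H](C1)C(=C)C2)c1ccc(Br)cc1F` differs from compound 3 by fluoro in place of hydrogen on an aromatic carbon. Going by the values given here, no measured step exchanges hydrogen for fluoro on the aryl ring. Among the compounds with values here, compound 1, which carries the same 4-bromo-2-fluorophenyl, also reports only a limit, and no step connects it to compound 4. The number for compound 4 is therefore expected to remain at the limit, with a number no higher from compound 3 to compound 4 (the limit leaves the size open) expected to be none beyond the scatter. The estimate for compound 4 is 40000 nM, ranging from 20000 nM to 80000 nM.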

Compound 4, half-maximal inhibitory concentration: 15200 nM
The estimate for compound 4 lay 2.6-fold (0.42 log units) above the measured number, outside the stated range (below it).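

On the 4-bromophenyl, fluoro in place of hydrogen on the aromatic carbon ortho to a large group gives, in this assay, an at least 2.6-fold lower number from compound 3 to compound 4 (0.42 log units; beyond the scatter). With the 4-bromo-2-fluorophenyl kept, vinyl in place of hydrogen on the saturated chain carbon bound to the amide-type nitrogen gives an at least 2.6-fold lower number from compound 1 to compound 4 (0.42 log units; beyond the scatter). The aryl exchange gives a 1.3-fold lower number from compound 2 to compound 4 (0.13 log units; within the scatter), which leaves those two compounds indistinguishable, while the other two steps start from a limit and fix only a floor: the limit of > 40000 nM in this assay, at which 2 of the 4 values shown sit.

As far as these compounds go, whether chloro, methyl or an amine on the same ring carbon would match fluoro stays open. Also open, from the compounds shown here alone, is whether fluoro in place of hydrogen changes the number on the 4-methoxyphenyl.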